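From an aminophenyl to a thiophene on a shared core

The source may hold more compounds than are shown below. What is called first, only, known or untested is meant among the compounds shown, and "the series" means these compounds.

Three compounds share a core in which a five-membered ring bearing three nitrogens links an amide to an aromatic group. Compound 1 `Nc1cccc(-c2cn(CC(=O)Nc3nccs3)nn2)c1` carries a 3-aminophenyl and in a functional assay on BMDM cells (Mus musculus, strain C57BL/6) for inhibition, with a stated time of 2 days (a higher number here means a weaker inhibitor, a lower number a stronger inhibitor), compound 1 gives 1270 nM. Compound 2 `O=C(Cn1cc(-c2ccccc2Cl)nn1)Nc1nccs1` carries a 2-chlorophenyl instead, and compound 2 gives 60 nM, a step recorded as a 21-fold lower number from compound 1 to compound 2 (1.33 log units; beyond the scatter). Compound 3 `Cc1csc(NC(=O)Cn2cc(-c3cccc(N)c3)nn2)n1` keeps the 3-aminophenyl of compound 1 but adds a methyl on the thiazole, and compound 3 gives 250 nM, a step recorded as a 5.1-fold lower number from compound 1 to compound 3 (0.71 log units; beyond the scatter). Compound 3 therefore stands second highest of the three numbers, between compound 2 and compound 1.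

Compound 4 `Cc1csc(NC(=O)Cn2cc(-c3cccs3)nn2)n1` is not yet measured. It differs from compound 3 in one place: thiophen-2-yl in place of 3-aminophenyl on an aromatic carbon. The step that bears on this change most directly is the swap away from 3-aminophenyl in going from compound 1 to compound 2, which gave a large drop; that swap introduced a different group, so its size is only a rough guide. Because the swap away from 3-aminophenyl already gave a 21-fold lower number from compound 1 to compound 2 (1.33 log units; beyond the scatter), a lower number is expected for compound 4 too, by roughly a 3.1-fold lower number from compound 3 to compound 4 (0.49 log units; beyond the scatter). Compound 4 is estimated at 80 nM, with a range from 25 nM to 300 nM.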

Compound 4, half-maximal inhibitory concentration: 40 nM
Estimate against measurement, compound 4: 2.0-fold (0.30 log units) above; measured number inside the range.
By their numbers in this assay, from the lowest: compounds 4 and 2 (each within the scatter of the next); then compound 3; then compound 1.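

On the aromatic carbon of the five-membered ring with three nitrogens, thiophen-2-yl in place of 3-aminophenyl gives a 6.3-fold lower number from compound 3 to compound 4 (0.80 log units; beyond the scatter) in this assay on a core that keeps the methyl. The earlier move away from 3-aminophenyl, to 2-chlorophenyl, went in the same direction but kept a six-membered aromatic ring of carbon only, whereas this change shows that such a ring is not needed at this position for a low number, since a five-membered aromatic ring with sulfur, with fewer heavy atoms and no hydrogen-bond donor, also gives one. Nothing measured here explains why the number falls with this change.

On these data alone, what remains open is whether the fall follows the loss of the amine or the change of ring, a question that a plain phenyl at the same position could help to separate. As far as these compounds go, it is also open whether the methyl lowers the number on a compound carrying thiophen-2-yl as it does on one carrying 3-aminophenyl, and an ethyl in its place would test how much room that spot allows.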